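The source may hold more compounds than are shown below. What is called first, only, known or untested is meant among the compounds shown, and "the series" means these compounds.

Working notes on the series, acid dissociation

Compound 1 `COc1cccc(CNCCCNc2ccnc3cc(Oc4ccc(Cl)cc4)ccc23)c1O` gives 9.28 in a physicochemical assay for acid dissociation. Compound 2 `COc1ccc(F)cc1CNCCCNc1ccnc2cc(C3CCCCC3)ccc12` gives 9.47 in this assay, and compound 3 `COc1ccc(F)cc1CNCCCNc1ccnc2cc(CCC(C)C)ccc12` gives 9.47 in this assay; both gaps to compound 1 lie within the scatter, so the three numbers sit together and compound 1 cannot be placed apart from the other two on this read-out.

For the measured compounds named here, the one step measured within the set is no change at the digits printed from compound 2 to compound 3 (within the scatter), a change of the substituent on the shared core remote from the protonatable amines, and it did not move the number.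

Compound 4 `COc1cccc(CNCCCNc2ccnc3cc(Oc4ccc(F)cc4)ccc23)c1O` is now to be measured in this assay. It differs from compound 1 by fluoro in place of chloro on an aromatic carbon, on an aromatic carbon of a six-membered aromatic ring of carbon only, para to a large group. Going by the values given here, no measured step covers this exchange; the only step on record, from compound 2 to compound 3, concerns a different group at a different place and shows the read-out holding steady when the aryl substituent is swapped. On that basis the step from compound 1 to compound 4 is expected to be no change at the digits printed from compound 1 to compound 4 (within the scatter), nothing beyond the scatter.

The estimate for compound 4 is therefore 9.28, within 9 to 9.56, pending the measurement.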

Compound 4, acid dissociation constant: 9.28
Compound 4: the middle estimate sits on the measured number at the digits printed; the measured number falls inside the stated range.
By their numbers in this assay, from the lowest: compounds 1, 4, 2 and 3 (each within the scatter of the next).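

In this assay the exchange of 4-chlorophenoxy to 4-fluorophenoxy on the shared core is the one step shown at this position, and it reads as a plain result (no change at the digits printed from compound 1 to compound 4 (within the scatter)). The earlier step (no change at the digits printed from compound 2 to compound 3 (within the scatter)) concerned a different group at a different place, so it said nothing about this position; the new step adds a direct reading for fluoro in place of chloro on an aromatic carbon of a six-membered aromatic ring of carbon only, para to a large group. No other measurement on these compounds bears on this result, so the step stands as an observation with no account of it.

Going by these compounds, only these two halogens have been compared at this position, so it remains open whether a larger or chemically different group there, such as an amine, a carboxylic acid or a nitrile in place of the halogen, would hold the number within the scatter or move it beyond. Also open, on these data alone, is whether the read-out would hold when the 4-chlorophenoxy group is replaced by a longer chain.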